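Acetyl in place of methyl on the piperazine ring

The source may report more compounds than this note shows. Statements on the series, on what has been measured and on what is new or still open speak of the compounds shown alone.

Measured compounds:
- compound 1, `CC(C)CN(Cc1ccc(N2CCN(C)CC2)cc1)S(=O)(=O)Cc1ccccc1`: 60000 nM
- compound 2, `COC1CCN(c2ccc(CN(CC(C)C)S(=O)(=O)Cc3ccccc3)cc2)CC1`: <= 1000 nM

Among the measured compounds shown here, in a physicochemical assay for solubility, in phosphate buffer, measured as kinetic solubility, with a stated time of 24 h, at pH 7.4 (a lower number here means a less soluble compound, a higher number a more soluble compound), compound 1 gives 60000 nM, the only plain number among the two values shown. Compound 2 reaches only (the limit of <= 1000 nM in this assay, at which 1 of the 2 values shown sits), a limit of the assay rather than a number. For the measured compounds named here, the one measured step, an at least 60-fold lower number from compound 1 to compound 2 (1.77 log units; beyond the scatter), is a large change at the same ring position that is altered here. Compound 3, `CC(=O)N1CCN(c2ccc(CN(CC(C)C)S(=O)(=O)Cc3ccccc3)cc2)CC1`, differs from compound 1 by acetyl in place of methyl on an amine nitrogen in a ring. Going by the values given here, no measured pair shows this exact change, so the step from compound 1 to compound 2 is the nearest guide, and it points toward a marked fall. Compound 3 is therefore expected to give 2500 nM, within 600 nM to 12000 nM. That estimated step, a 24-fold lower number from compound 1 to compound 3 (1.38 log units; beyond the scatter), is smaller than the measured step to compound 2 but still beyond the scatter, and a limit rather than a number is quite possible.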

Compound 3, solubility: <= 1000 nM
Compound 3: a limit, no number (the forecaster's own chance of this, stated with the estimate: 35%); at least 2.5-fold (0.39 log units) between middle value and limit.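

Keeping the piperazine ring and changing only the group on its amine nitrogen, methyl to acetyl, is enough to give an at least 60-fold lower number from compound 1 to compound 3 (1.77 log units; beyond the scatter), so the earlier fall did not depend on replacing that ring with 4-methoxypiperidin-1-yl. In this assay, among the compounds shown here, compound 3 gives a limit and not a number, so the true size of this fall is not known, and compound 1 remains the only compound with a plain number: the limit of <= 1000 nM in this assay, at which 2 of the 3 values shown sit. The steps between compound 2 and compound 3 cannot be read, so these two groups cannot be placed in order.

On these data alone, whether a smaller change at this nitrogen, such as ethyl in place of methyl, would keep a plain number remains open. So does the result for a free amine at this position, with hydrogen in place of methyl.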